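This account rests on a few compounds, and the source may have more. Where it says the series, first, only, none or still open, it means among the compounds named here.

Working notes on the series. For the measured compounds named here, the shared core carries a butanediyl linker to an aryl carboxylic acid, and the two measured members differ only in that aryl group. Compound 1 `Cc1c(OCCCCOc2ccc(C(=O)O)cc2F)ccc(C(=O)CC2CCCC2)c1O` in an assay on HEK293 cells for positive allosteric modulation of metabotropic glutamate receptor 3 (Rattus norvegicus), read by thallium flux, with a stated time of 2.5 min (on this read-out higher numbers stand for larger maximal responses and lower numbers for smaller maximal responses), gives 31.2%, and compound 2 `Cc1c(OCCCCOc2ccccc2C(=O)O)ccc(C(=O)CC2CCCC2)c1O` in this assay gives 32.9%; the change is a number 1.7 percentage points higher from compound 1 to compound 2 (within the scatter), so the two stand together within the usual scatter and neither can be called the larger response.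

Compound 3 `Cc1c(OCCCCOc2cccc(C(=O)O)c2)ccc(C(=O)CC2CCCC2)c1O` has not yet been measured. It differs from compound 2 by 3-carboxyphenyl in place of 2-carboxyphenyl on an oxygen on a saturated carbon. Going by the values given here, the only step that bears on this is the one from compound 1 to compound 2, where moving the carboxyl between two positions of the phenyl ring and removing a fluorine left the maximal response unchanged within the scatter. A further shift of the carboxyl to the 3-position therefore gives no basis to expect a step beyond the scatter in either direction. Compound 3 is estimated to reach 32%, with a range from 22% to 44%, meaning an expected step of a number 0.9 percentage points lower from compound 2 to compound 3 (within the scatter).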

Compound 3, largest response reached (reported as percent of maximum), in percent of the reference or control that the assay uses: 92.9%
For compound 3 the middle estimate is 60.9 percentage points below the measured one, and the stated range ends below it.
By their numbers in this assay, from the lowest: compounds 1 and 2 (each within the scatter of the next); then compound 3.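

For the compounds shown here, the placement of the carboxyl on the aryl group is a strong determinant of the largest response in this assay, which the first pair of compounds did not reveal: with the same atoms joined differently, 3-carboxyphenyl in place of 2-carboxyphenyl gives a number 60 percentage points higher from compound 2 to compound 3 (beyond the scatter) on the same shared core. The change from 4-carboxy-2-fluorophenyl to 3-carboxyphenyl gives a number 61.7 percentage points higher from compound 1 to compound 3 (beyond the scatter), so the earlier result, a number 1.7 percentage points higher from compound 1 to compound 2 (within the scatter), did not mean that the response was insensitive to this aryl group. Nothing in hand accounts for the larger response of the 3-carboxyphenyl group.

The compounds shown leave open how a fluorine would act on the 3-carboxyphenyl group, and how an unfluorinated 4-carboxyphenyl group would compare, since compound 1 differs from compound 3 in both the carboxyl placement and the fluorine. They also leave open whether a tetrazole or a primary amide could stand in for the carboxylic acid on the 3-substituted phenyl ring, and whether a shorter or longer chain than the butanediyl linker would hold the response.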